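A Fluorine Enters the Fused Ring of Compound 1

The source may hold more compounds than are shown below. What is called first, only, known or untested is meant among the compounds shown, and "the series" means these compounds.

Going by the values given here, compound 1 `COc1cc2c(Oc3ccc(NC(=O)c4cc(-c5ccccc5)nc5ccccc45)cc3F)ccnc2cc1OCCCN1CCCCC1` gives 110 nM in a functional assay on NCI-H460 cells (Homo sapiens) for cytotoxicity, read by MTT assay, with a stated time of 72 h (a lower number here means a stronger inhibitor, a higher number a weaker inhibitor), the higher of the two numbers known, although compound 2 `COc1cc2c(Oc3ccc(NC(=O)c4cc(-c5ccccc5)nc5ccccc45)cc3F)ccnc2cc1OCCCN1CCC(C)CC1` gives 68 nM and the step of a 1.6-fold lower number from compound 1 to compound 2 (0.21 log units; within the scatter) stays within the scatter. Compound 3 `COc1cc2c(Oc3ccc(NC(=O)c4cc(-c5ccccc5)nc5ccc(F)cc45)cc3F)ccnc2cc1OCCCN1CCCCC1` differs from compound 1 by fluoro in place of hydrogen on an aromatic carbon. Among the compounds with values here, no measured step touches this aromatic position; the single step known concerns the saturated ring and was small. For compound 3 a step of comparable size, or none beyond the scatter, is therefore expected: a 1.1-fold lower number from compound 1 to compound 3 (0.04 log units; within the scatter). Compound 3 is estimated at 100 nM, with a range from 40 nM to 250 nM.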

Compound 3, half-maximal inhibitory concentration: 32 nM
Compound 3: the middle estimate sits 3.1-fold (0.49 log units) above what was measured; measured number below the stated range.
By their numbers in this assay, from the lowest: compound 3; then compounds 2 and 1 (each within the scatter of the next).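

In this assay, fluoro on an aromatic carbon of the six-membered ring of carbon only gives a 3.4-fold lower number from compound 1 to compound 3 (0.54 log units; beyond the scatter), the only step among these compounds that lies beyond the scatter. This shows that the aromatic position responds, if modestly, to a single fluorine atom, which the earlier step on the saturated ring did not show. Nothing available accounts for the size of this step. Going by these compounds, whether chloro or methoxy on the same aromatic carbon would give a similar step remains open. So does whether fluoro would give a similar step alongside the methyl on the saturated ring of compound 2.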